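The compounds below may be only part of what the source reports. "The series", "measured", "known", "first", "only" and "open" are said of these compounds alone.

Measured compounds:
Compound 1 `Cc1cc(/C=C/C#N)cc(C)c1Oc1cc(Nc2ccc(C#N)cc2)c(N)cc1C(F)(F)F`, in an in vitro ADME assay on microsomes from liver (Homo sapiens) for metabolic stability, tested at 1 uM (a lower number here means that the compound disappears faster, a higher number that the compound lasts longer), compound 1 gives 0.75 h.
Compound 2 `Cc1cc(/C=C/C#N)cc(C)c1Oc1cc(Nc2ccc(C#N)cc2)c(N)cc1CO`, in this assay compound 2 gives 0.503 h.

Compound 2 holds the lowest of the two numbers in this assay, with compound 1 as its nearest neighbour; the gap between them, a 1.5-fold lower number from compound 1 to compound 2 (0.17 log units; within the scatter), is within the scatter. Compound 3 `Cc1cc(/C=C/C#N)cc(C)c1Oc1cc(Nc2ccc(C#N)cc2)c(N)cc1C(N)=O` differs from compound 2 in one place: carbamoyl in place of hydroxymethyl on an aromatic carbon. Among the compounds with values here, no measured step in this assay covers this exact change; the only step available, a 1.5-fold lower number from compound 1 to compound 2 (0.17 log units; within the scatter), concerns a different exchange at the same aromatic carbon and stayed within the scatter. Compound 3 is therefore expected to sit close to compound 2 in this assay, with a step of a 1.2-fold higher number from compound 2 to compound 3 (0.08 log units; within the scatter), not beyond the scatter. The estimate for compound 3 in this assay is 0.6 h, in a range from 0.3 h to 1.2 h.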

Compound 3, half-life: 0.583 h
Compound 3: the middle estimate sits 1.0-fold (0.01 log units) above what was measured; measured number inside the range.
By their numbers in this assay, from the lowest: compounds 2, 3 and 1 (each within the scatter of the next).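

At the aromatic carbon para to the (4-cyanophenyl)amino group, carbamoyl gives a 1.2-fold higher number from compound 2 to compound 3 (0.06 log units; within the scatter) in this assay and a 1.3-fold lower number from compound 1 to compound 3 (0.11 log units; within the scatter) against trifluoromethyl. The earlier pair had shown only hydroxymethyl and trifluoromethyl within the scatter of each other; with carbamoyl, all three groups at this carbon now lie within the scatter, so none of these exchanges separates the compounds in half-life. Nothing available bears on the cause of this result.

From the compounds shown here alone, it remains open whether a carboxylic acid, an amine or a longer chain at this carbon would shift the half-life beyond the scatter. Going by these compounds, it also remains open whether these three groups would read alike if the shared core were changed elsewhere, for instance at the amino group.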